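Chromone carboxamides: amide aryl ring and monoamine oxidase B inhibition

The source may hold more compounds than are shown below. What is called first, only, known or untested is meant among the compounds shown, and "the series" means these compounds.

Measured so far:
compound 1 `Cc1cccc(NC(=O)c2cc3cc(C)ccc3oc2=O)c1`, 7.52 nM;
compound 2 `Cc1ccc2occ(C(=O)Nc3cccc(Cl)c3)c(=O)c2c1`, 4.2 nM;
compound 3 `Cc1ccc(NC(=O)c2coc3ccc(C)cc3c2=O)cc1`, 152 nM.

In an assay on cells for inhibition of Amine oxidase [flavin-containing] B (Homo sapiens), read by fluorescence and Amplex Red, using microsomes, with a stated time of 15 min (on this read-out higher numbers stand for weaker inhibition and lower numbers for stronger inhibition), compound 3 stands highest of the three, beyond the scatter from both compound 1 and compound 2. Going by the values given here, the one single-point step recorded, a 36-fold higher number from compound 2 to compound 3 (1.56 log units; beyond the scatter), shows that the aryl group on the amide nitrogen moves the numbers strongly. Compound 4 `Cc1ccc2occ(C(=O)Nc3ccc(O)cc3)c(=O)c2c1` differs from compound 3 by hydroxy in place of methyl on an aromatic carbon. Among the compounds with values here, no measured pair tests a hydroxy at this position, so the direction is open; the recorded step only indicates that this ring is sensitive. A moderate rise is expected, a 3.3-fold higher number from compound 3 to compound 4 (0.52 log units; beyond the scatter), with wide uncertainty. Compound 4 is therefore estimated at 500 nM, range 100 nM to 3000 nM.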

Compound 4, half-maximal inhibitory concentration: 513 nM
Beside the measured number, compound 4's estimate is 1.0-fold (0.01 log units) below it; the range from low to high includes it.
By their numbers in this assay, from the lowest: compounds 2 and 1 (each within the scatter of the next); then compound 3; then compound 4.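

Hydroxy in place of methyl, on the carbon para to a large group, gives a 3.4-fold higher number from compound 3 to compound 4 (0.53 log units; beyond the scatter) and so shows that this carbon alone moves the number beyond the scatter. With 4-hydroxyphenyl in place of 3-chlorophenyl on the amide nitrogen, there is a 120-fold higher number from compound 2 to compound 4 (2.09 log units; beyond the scatter) and compound 4 stands highest of the four. No supporting data give a cause for either step.

Open, going by these compounds, is how an amine or a methoxy group would read at this same carbon. Also open, on these data alone, is whether hydroxy in place of the chlorine of compound 2 would give a similar rise.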